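From isobutyl to thiophen-2-yl on a sulfur

A few compounds are considered here, and "the series" means these few. Any claim that something is new, unique, unknown or untested is made for them only; others in the source may bear on it.

In an ADME assay on cells (Fibroblast, Gallus gallus) for cytotoxicity, read by CCK-8 assay, with a stated time of 48 h (on this read-out lower numbers stand for higher toxicity in this test and higher numbers for lower toxicity in this test), compound 1 `CCc1ccc(CN[C@H]2CC(C(=O)O)=C[C@@H](OC(CC)CC)[C@@H]2NC(C)=O)cc1` gives > 200000 nM as a limit of the assay, not a number. Compound 2 `CCC(CC)O[C@@H]1C=C(C(=O)O)C[C@H](NCc2ccc(OC)cc2)[C@H]1NC(C)=O` gives > 200000 nM as a limit too. Compound 3 `CCC(CC)O[C@@H]1C=C(C(=O)O)C[C@H](NCc2ccc(SCC(C)C)cc2)[C@H]1NC(C)=O` gives > 200000 nM as a limit as well. So compound 3 has no exact value and stands with the other two at the limit of > 200000 nM in this assay, at which 3 of the 3 values shown sit, in this series.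

Compound 4 `CCC(CC)O[C@@H]1C=C(C(=O)O)C[C@H](NCc2ccc(Sc3cccs3)cc2)[C@H]1NC(C)=O` carries thiophen-2-yl in place of isobutyl on a sulfur and keeps the rest of compound 3 unchanged.

The measured steps that bear on this swap are a step that the two limits leave unreadable from compound 1 to compound 3 and a step that the two limits leave unreadable from compound 2 to compound 3 and a step that the two limits leave unreadable from compound 1 to compound 2 and none of them yields a size. Changing the group on that aromatic carbon has left all three compounds at a limit in this assay so no shift beyond the scatter is expected, in either direction. The expected outcome is a number no higher from compound 3 to compound 4 (the limit leaves the size open) for this swap. Compound 4 is estimated at 200000 nM with an expected range from 100000 nM to 400000 nM and a limit of the assay is again expected for it.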

Compound 4, half-maximal cytotoxic concentration: > 200000 nM
Compound 4: only a limit was reported (the forecaster's own chance of this, stated with the estimate: 70%); the middle value sits exactly at the limit.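

Compound 4 is reported only as a limit, as are compounds 1, 2 and 3, so no step among these four compounds can be read: the limit of > 200000 nM in this assay, at which 4 of the 4 values shown sit.

The compounds shown leave open how much cytotoxicity any of them has in this assay, and whether any change to the group would yield an exact value.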